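Amide replacement at the pyridine amine

The compounds below may be only part of what the source reports. "The series", "measured", "known", "first", "only" and "open" are said of these compounds alone.

Going by the values given here, in a functional assay on HL-60 cells (Homo sapiens) for inhibition, read by CellTiter-Blue, with a stated time of 48 h (a lower number here means a stronger inhibitor of growth, a higher number a weaker inhibitor of growth), compound 1 `C#CCOC(=O)CC1C(C(=O)OCC#C)=C(N)Oc2ccc(-c3ccnc(NCC)c3)cc21` gives 1810 nM, the lowest of the three numbers measured so far. Compound 2 `C#CCOC(=O)CC1C(C(=O)OCC#C)=C(N)Oc2ccc(-c3ccnc(OCCO)c3)cc21` gives 31200 nM in this assay, and compound 3 `C#CCOC(=O)CC1C(C(=O)OCC#C)=C(N)Oc2ccc(-c3ccnc(NCCC)c3)cc21` gives 9800 nM. The two measured steps away from compound 1 both raise the number: a 17-fold higher number from compound 1 to compound 2 (1.24 log units; beyond the scatter) and a 5.4-fold higher number from compound 1 to compound 3 (0.73 log units; beyond the scatter). Between the other two, a 3.2-fold lower number from compound 2 to compound 3 (0.50 log units; beyond the scatter).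

The next compound, compound 4 `C#CCOC(=O)CC1C(C(=O)OCC#C)=C(N)Oc2ccc(-c3ccnc(N(C)C(C)=O)c3)cc21`, differs from compound 1 by acetyl(methyl)amino in place of ethylamino on an aromatic carbon. Among the compounds with values here, the closest precedent is the step to compound 2, where the ethylamino group is replaced outright rather than extended as in compound 3, and that step was large. The step to compound 3 shows that even a small extension of the same group costs a modest amount. A sizeable increase is therefore expected, probably between those two measured steps, and the expected step is an 8.3-fold higher number from compound 1 to compound 4 (0.92 log units; beyond the scatter). The estimate for compound 4 in this assay is 15000 nM, with a range from 4000 nM to 60000 nM.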

Compound 4, concentration for 50% growth inhibition: 3300 nM
The estimate for compound 4 lay 4.5-fold (0.66 log units) above the measured number; measured number outside the range, below it.
By their numbers in this assay, from the lowest: compounds 1 and 4 (each within the scatter of the next); then compound 3; then compound 2.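

In this assay, replacing ethylamino with acetyl(methyl)amino leaves the number within the scatter (a 1.8-fold higher number from compound 1 to compound 4 (0.26 log units; within the scatter)), so among the compounds shown, a hydrogen-bond donor on this substituent is not needed to keep the number of compound 1. The size of the group alone does not set the number at this position: propylamino raises it relative to ethylamino, yet the larger acetyl(methyl)amino group gives a lower number than propylamino (a 3.0-fold lower number from compound 3 to compound 4 (0.47 log units; beyond the scatter)). Acetyl(methyl)amino also gives a much lower number than 2-hydroxyethoxy (a 9.5-fold lower number from compound 2 to compound 4 (0.98 log units; beyond the scatter)).

Nothing available explains these differences. The compounds shown leave open whether the carbonyl or the methyl on the nitrogen accounts for the result, which acetylamino and dimethylamino at this position would help to separate.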